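Working notes: aryl exchange from compound 3 to compound 4

This account rests on a few compounds, and the source may have more. Where it says the series, first, only, none or still open, it means among the compounds named here.

Measured in an ADME assay on cells (Macrophage) for cytotoxicity, read by MTT assay, with a stated time of 24 h; on this read-out lower numbers stand for higher toxicity in this test and higher numbers for lower toxicity in this test:
- compound 1 `Cc1ccc(/C=C/C(=O)NNC(=O)c2ccc3c(c2)OCCO3)cc1`: 332000 nM
- compound 2 `O=C(/C=C/c1cccc([N+](=O)[O-])c1)NNC(=O)c1ccc2c(c1)OCCO2`: 323000 nM
- compound 3 `O=C(/C=C/c1ccccc1[N+](=O)[O-])NNC(=O)c1ccc2c(c1)OCCO2`: 257000 nM

In this assay compound 3, at 257000 nM, stands within the scatter of both other compounds, as a 1.3-fold lower number from compound 2 to compound 3 (0.10 log units; within the scatter) and a 1.3-fold lower number from compound 1 to compound 3 (0.11 log units; within the scatter) show.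

Compound 4 `COc1cccc(/C=C/C(=O)NNC(=O)c2ccc3c(c2)OCCO3)c1` has not yet been measured. It carries 3-methoxyphenyl in place of 2-nitrophenyl on a double-bonded chain carbon bound to a double-bonded chain carbon.

Going by the values given here, the steps that bear on this change are the three exchanges at that same place. Besides the two above, there is a 1.0-fold lower number from compound 1 to compound 2 (0.01 log units; within the scatter). Among the compounds with values here, all three stay within the scatter, so the series so far offers no exchange of this group with a visible effect. Within the data shown here, no compound with 3-methoxyphenyl has been measured, which leaves some uncertainty. No step beyond the scatter is expected in this assay, and the expected step is a 1.2-fold higher number from compound 3 to compound 4 (0.07 log units; within the scatter). For compound 4 the estimate is 300000 nM, with an expected range of 180000 nM to 480000 nM.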

Compound 4, half-maximal cytotoxic concentration: 398000 nM
Beside the measured number, compound 4's estimate is 1.3-fold (0.12 log units) below it; the range from low to high includes it.
By their numbers in this assay, from the lowest: compounds 3, 2, 1 and 4 (each within the scatter of the next).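

With 3-methoxyphenyl on a double-bonded chain carbon bound to a double-bonded chain carbon, the number in this assay remains within the scatter of the earlier aryl groups (a 1.5-fold higher number from compound 3 to compound 4 (0.19 log units; within the scatter)). The same holds for methoxy in place of nitro on an aromatic carbon (a 1.2-fold higher number from compound 2 to compound 4 (0.09 log units; within the scatter)) and for 3-methoxyphenyl in place of 4-methylphenyl (a 1.2-fold higher number from compound 1 to compound 4 (0.08 log units; within the scatter)). This position has therefore now taken four aryl groups, including a methoxy-bearing one for the first time, without a step beyond the scatter, and no measurement shown here bears on the reason for this.

Still open, from the compounds shown here alone, is whether an aryl group carrying an amine or a carboxylic acid, or a longer chain in place of the aryl group, would move the number beyond the scatter. Also open, going by these compounds, is whether any change to the shared core would do so.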